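The compounds below may be only part of what the source reports. "The series", "measured", "known", "first", "only" and "open" are said of these compounds alone.

Measured so far:
compound 1, `O=C(Nc1nc(-c2ccccc2)nc2c1nnn2Cc1ccccc1)c1cccc([N+](=O)[O-])c1`, in an assay (strain Wistar) for displacement of a labelled ligand from adenosine receptor A1 (Rattus norvegicus), read by scintillation counting (a higher number here means a weaker inhibitor, a lower number a stronger inhibitor), gives 77 nM;
compound 2, `O=C(Nc1nc(-c2ccccc2)nc2c1nnn2Cc1ccccc1)c1ccccc1C(F)(F)F`, in this assay gives 550 nM.

Compound 2 holds the highest of the two numbers, and its nearest neighbour is compound 1, with a 7.1-fold higher number from compound 1 to compound 2 (0.85 log units; beyond the scatter) between them. The unmeasured compound 3, `O=C(Nc1nc(-c2ccccc2)nc2c1nnn2Cc1ccccc1)c1cccc(C(F)(F)F)c1`, differs from compound 2 in one place: 3-(trifluoromethyl)phenyl in place of 2-(trifluoromethyl)phenyl on a carbonyl carbon. Among the measured compounds shown here, only one measured step touches this change, and it does so partly, since it swaps 3-nitrophenyl for 2-(trifluoromethyl)phenyl, altering both the group and its name at once; it was a 7.1-fold higher number from compound 1 to compound 2 (0.85 log units; beyond the scatter). For the measured compounds named here, no step isolates the trifluoromethyl group's move on its own. Going by the values given here, the single comparison at hand suggests that compound 3 is expected to sit between its two neighbours, and compound 3 is estimated at 200 nM in this assay, with a range from 60 nM to 700 nM, which amounts to an expected step of a 2.8-fold lower number from compound 2 to compound 3 (0.44 log units; beyond the scatter), downward but uncertain.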

Compound 3, inhibition constant: 163 nM
Beside the measured number, compound 3's estimate is 1.2-fold (0.09 log units) above it; low and high end bracket the measured number.
By their numbers in this assay, from the lowest: compound 1; then compound 3; then compound 2.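

With the atoms unchanged, putting 3-(trifluoromethyl)phenyl in place of 2-(trifluoromethyl)phenyl on the carbonyl carbon in this assay gives a 3.4-fold lower number from compound 2 to compound 3 (0.53 log units; beyond the scatter) and so shows that the group's place on the ring alone shifts the number. Trifluoromethyl in place of nitro on an aromatic carbon gives a 2.1-fold higher number from compound 1 to compound 3 (0.33 log units; beyond the scatter) as a second step beyond the scatter, so the earlier step that changed group and place together can now be read as two separate changes, each of which matters. Nothing available explains either step. The compounds shown leave open how an amine or a carboxylic acid in place of nitro on that aromatic carbon would read in this assay. They also leave open whether moving the nitro group would produce a step like the one seen for trifluoromethyl.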